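The source may hold more compounds than are shown below. What is called first, only, known or untested is meant among the compounds shown, and "the series" means these compounds.

Of the compounds shown here, three built on one shared core have been tested in a functional assay on HCT-116 cells (Homo sapiens) for antiproliferative activity, read by CCK-8 assay, with a stated time of 72 h; a lower number here means a stronger inhibitor, a higher number a weaker inhibitor. Compound 1 `CC1=NN(c2cccc(Cl)c2)C(=O)C12C=CC(=O)C=C2c1cccc(C)c1` gives 3740 nM. Compound 2 `CC1=NN(c2ccccc2)C(=O)C12C=CC(=O)C=C2c1cccc(C)c1` gives only > 100000 nM, which is a limit of the assay and not a number. Compound 3 `CC1=NN(c2ccc(Cl)cc2)C(=O)C12C=CC(=O)C=C2c1cccc(C)c1` gives 13300 nM, the highest of the two numbers recorded, and a 3.6-fold higher number from compound 1 to compound 3 (0.55 log units; beyond the scatter). Taking the chloro away gives an at least 26-fold higher number from compound 1 to compound 2 (1.42 log units; beyond the scatter), and putting it back gives an at least 7.5-fold lower number from compound 2 to compound 3 (0.87 log units; beyond the scatter).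

Compound 4 `CC1=NN(c2ccc(Br)cc2)C(=O)C12C=CC(=O)C=C2c1cccc(C)c1` differs from compound 3 by bromo in place of chloro on an aromatic carbon, that is, 4-chlorophenyl to 4-bromophenyl, on an aromatic carbon of a six-membered aromatic ring of carbon only, para to a large group. Going by the values given here, none of the measured steps exchanges one halogen for another: the steps from compound 1 to compound 2 and from compound 2 to compound 3 concern whether a halogen is present, and the step from compound 1 to compound 3 concerns where it sits. Since a chloro in place of hydrogen gave an at least 7.5-fold lower number from compound 2 to compound 3 (0.87 log units; beyond the scatter), a bromo at the same place is expected to behave much like the chloro, and the step of a 1.3-fold lower number from compound 3 to compound 4 (0.12 log units; within the scatter) is expected to stay within the scatter. Compound 4 is therefore estimated at 10000 nM in this assay, with a range from 4000 nM to 30000 nM.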

Compound 4, half-maximal inhibitory concentration: > 100000 nM
Compound 4 was reported as a limit (the forecaster's own chance of this, stated with the estimate: 5%); at least 10-fold (1.00 log units) between middle value and limit.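

At this place, para to a large group, the exchange of one halogen for another in this assay is far from neutral: bromo in place of chloro gives an at least 7.5-fold higher number from compound 3 to compound 4 (0.87 log units; beyond the scatter) and so separates two compounds that differ by a single atom. Compound 4 gives > 100000 nM, which is a limit of the assay and not a number. Against the 3-chlorophenyl group of compound 1, the 4-bromophenyl group gives an at least 26-fold higher number from compound 1 to compound 4 (1.42 log units; beyond the scatter) and so shows that a halogen on this aromatic ring does not by itself keep a measurable number, since compound 1 and compound 3 have one and compound 4 does not.

The step from compound 2 to compound 4 cannot be read, because both stand at the same limit: the limit of > 100000 nM in this assay, at which 2 of the 4 values shown sit. Open remain how far compound 4 lies beyond that limit, how a bromo would behave at the place the chloro holds in compound 1, and whether a fluoro, a methyl, an amine or a carboxylic acid at the place para to a large group would give a number closer to that of compound 3 or to the limit.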